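Aryl change at the shared core: compound 2 to compound 4

The compounds below may be only part of what the source reports. "The series", "measured", "known", "first", "only" and "open" are said of these compounds alone.

Measured so far in a functional assay on CHO-K1 cells for antagonist activity at adenosine receptor A1 (Homo sapiens), read by a beta-galactosidase reporter and cAMP accumulation, with stated times of 15 min and 6 h; a higher number here means a weaker inhibitor, a lower number a stronger inhibitor:
compound 1 `Cc1ccc(-c2nc(N)c3cc(Cc4ccccc4Cl)sc3n2)o1` gives 26.1 nM
compound 2 `Nc1nc(-c2ccc(C(F)F)o2)nc2sc(Cc3ccccc3)cc12` gives 3000 nM
compound 3 `COc1ccccc1Cc1cc2c(N)nc(-c3ccc(C(F)F)o3)nc2s1` gives 516 nM

Compound 2 stands at the highest number of the three. Its nearest neighbour is compound 3, reached by a 5.8-fold lower number from compound 2 to compound 3 (0.76 log units; beyond the scatter). Compound 1 differs from compound 2 in two places, so its two values are only compared, not stepped.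

Compound 4 `Nc1nc(-c2ccccn2)nc2sc(Cc3ccccc3)cc12` is reached from compound 2 by pyridin-2-yl in place of 5-(difluoromethyl)furan-2-yl on an aromatic carbon. Going by the values given here, no measured step changes the group at this position; the one measured step concerns the benzyl substituent and does not bear on the aryl change. Among the compounds with values here, with no direct precedent, the expected step of a 2.0-fold lower number from compound 2 to compound 4 (0.30 log units; within the scatter) is set close to none beyond the scatter, leaning slightly downward. Compound 4 is therefore estimated at 1500 nM in this assay, within 300 nM to 8000 nM.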

Compound 4, inhibition constant: 3710 nM
Estimate against measurement, compound 4: 2.5-fold (0.39 log units) below; the measured number falls inside the stated range.
By their numbers in this assay, from the lowest: compound 1; then compound 3; then compounds 2 and 4 (each within the scatter of the next).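

In this assay, pyridin-2-yl in place of 5-(difluoromethyl)furan-2-yl gives a 1.2-fold higher number from compound 2 to compound 4 (0.09 log units; within the scatter) and so does not separate the two compounds. At this aromatic carbon between two ring nitrogen atoms, a six-membered aromatic ring and a substituted five-membered one therefore read alike, unlike the change on the benzyl substituent, a 5.8-fold lower number from compound 2 to compound 3 (0.76 log units; beyond the scatter) and so beyond the scatter. No supporting data explain this result.

As far as these compounds go, whether a morpholine or a carboxylic acid at this position would read differently remains open. So does whether the methoxy step holds with pyridin-2-yl in place.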